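The source may hold more compounds than are shown below. What is called first, only, known or untested is meant among the compounds shown, and "the series" means these compounds.

In a functional assay on cells (Endothelial cell, Bos taurus) for antiproliferative activity (a higher number here means a weaker inhibitor, a lower number a stronger inhibitor), compound 1 `COc1ccc(/C(F)=C/c2cc(OC)c(OC)c(OC)c2)cc1F` gives 610000 nM, the higher of the two numbers in hand. Compound 2 `COc1cc(/C=C/c2cc(O)c3ccsc3c2)cc(OC)c1OC` gives 38000 nM, lower than compound 1 by more than the scatter, although the two differ in more than one place. The next compound to be tested is compound 3 `COc1ccc(/C(F)=C/c2cc(OC)c(OC)c(OC)c2)cc1O`, which changes compound 1 at a single position: hydroxy in place of fluoro on an aromatic carbon. There, hydroxy replaces fluoro on an aromatic carbon, ortho to a methoxy group. Among the compounds with values here, no measured pair shows this exchange, so the expectation is only loosely supported. Compound 2, which also carries a hydroxy group, stands at 38000 nM, and this points to a moderate drop beyond the scatter, towards stronger inhibition. The expected change is a 10-fold lower number from compound 1 to compound 3 (1.01 log units; beyond the scatter). For compound 3 the estimated value is 60000 nM, with an expected range of 8000 nM to 300000 nM.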

Compound 3, half-maximal inhibitory concentration: 26600 nM
Compound 3: the middle estimate sits 2.3-fold (0.35 log units) above what was measured; measured number inside the range.
By their numbers in this assay, from the lowest: compounds 3 and 2 (each within the scatter of the next); then compound 1.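

In this assay, within the data shown here, hydroxy in place of fluoro on this aromatic carbon, ortho to a methoxy group, gives a 23-fold lower number from compound 1 to compound 3 (1.36 log units; beyond the scatter), the first step here that can be read at a single place, and it shows that this position bears strongly on the read-out. The exchange brings in one hydrogen-bond donor and one hydrogen-bond acceptor where fluoro counted none, but a single step cannot tell whether either count matters. Nothing measured here accounts for the size of this step.

The compounds shown leave open whether the step depends on hydroxy itself or on the loss of fluoro, as no amine, chloro group or plain hydrogen stands at this position among them. On these data alone, whether the same exchange would give a step of similar size on another core, such as that of compound 2, also remains open.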